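Working notes: the step to compound 3

This account rests on a few compounds, and the source may have more. Where it says the series, first, only, none or still open, it means among the compounds named here.

In an in vitro ADME assay on microsomes from liver (Mus musculus) for pharmacokinetics, read by LC-MS, with a stated time of 10 min, tested at 1 uM (on this read-out higher numbers stand for fast clearance and lower numbers for slow clearance), compound 1 `CN1C[C@H](C(=O)Nc2ccccc2)[C@@H](c2ccc(/C=C/C(=O)Nc3ccccc3N)cc2)C1` gives 67 mL/min/kg and compound 2 `CN1C[C@H](C(=O)Nc2cccc(Cl)c2)[C@@H](c2ccc(/C=C/C(=O)Nc3ccccc3N)cc2)C1` gives 58 mL/min/kg, so compound 2 stands level with compound 1 within the scatter. Compound 3 `CN1C[C@H](C(=O)Nc2ccccc2F)[C@@H](c2ccc(/C=C/C(=O)Nc3ccccc3N)cc2)C1` differs from compound 2 by 2-fluorophenyl in place of 3-chlorophenyl on an amide-type nitrogen, in words 2-fluorophenyl in place of 3-chlorophenyl on an amide-type nitrogen. Within the data shown here, the only measured step that bears on this is a 1.2-fold lower number from compound 1 to compound 2 (0.06 log units; within the scatter), for chloro in place of hydrogen on an aromatic carbon. Among the measured compounds shown here, no measured compound carries fluorine, so that step is only a loose guide. As that one step stays small, no step beyond the scatter is expected in this assay. The expected step is a 1.0-fold higher number from compound 2 to compound 3 (0.01 log units; within the scatter). The estimated clearance of compound 3 is 60 mL/min/kg, with an expected range of 35 mL/min/kg to 95 mL/min/kg.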

Compound 3, clearance: 67 mL/min/kg
The estimate for compound 3 lay 1.1-fold (0.05 log units) below the measured number; the range from low to high includes it.
By their numbers in this assay, from the lowest: compounds 2, 1 and 3 (each within the scatter of the next).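

In this assay, 2-fluorophenyl in place of 3-chlorophenyl on the amide-type nitrogen gives a 1.2-fold higher number from compound 2 to compound 3 (0.06 log units; within the scatter) in this series, and adding fluoro to the unsubstituted phenyl gives no change at the digits printed from compound 1 to compound 3 (within the scatter) for the other pair. Fluoro now joins hydrogen and chloro on this aromatic ring, and none of the three steps among compounds 1, 2 and 3 lies beyond the scatter, so neither halogen, each in its own place, separates from the unsubstituted phenyl. Nothing available explains this flat result.

The compounds shown leave open whether 3-fluorophenyl or 2-chlorophenyl would tell the identity of the halogen apart from its place on the ring. They also leave open whether a carboxylic acid or a dimethylamino group on this ring would give a step beyond the scatter.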